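A few compounds are considered here, and "the series" means these few. Any claim that something is new, unique, unknown or untested is made for them only; others in the source may bear on it.

Three compounds of the shared core have so far been run in an assay on HEK293 cells for displacement of a labelled ligand from Melanocortin receptor 4 (Homo sapiens); on this read-out higher numbers stand for weaker inhibition and lower numbers for stronger inhibition. Compound 1 `CC(C)C[C@H](N)c1cc(C(F)(F)F)ccc1N1CCN(C(=O)CCNC2CCCCC2)CC1` gives 4800 nM. Compound 2 `CC(C)C[C@H](N)c1cc(C(F)(F)F)ccc1N1CCN(C(=O)COc2ccc(O)cc2)CC1` gives 4600 nM, and compound 3 `CC(C)C[C@H](N)c1cc(C(F)(F)F)ccc1N1CCN(C(=O)CCC2CCCCC2)CC1` gives 5700 nM. Compound 1 thus holds the second highest of the three numbers; its nearest step is a 1.0-fold lower number from compound 1 to compound 2 (0.02 log units; within the scatter) and its furthest is a 1.2-fold higher number from compound 1 to compound 3 (0.07 log units; within the scatter). The remaining pair shows a 1.2-fold higher number from compound 2 to compound 3 (0.09 log units; within the scatter). All three steps sit within the scatter, so no order can be read among compounds 1, 2 and 3 in this assay.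

Compound 4 `CC(C)C[C@H](N)c1cc(C(F)(F)F)ccc1N1CCN(C(=O)CSc2ccc(Cl)cc2Cl)CC1` has not yet been measured. It differs from compound 1 by (2,4-dichlorophenyl)sulfanyl in place of (cyclohexylamino)methyl on a saturated chain carbon bound to a carbonyl carbon. For the measured compounds named here, the steps that bear on this exchange are the two made at the same place, on the saturated chain carbon bound to the carbonyl carbon, plus the one made two bonds along the chain; none of them shifted this assay beyond the scatter, whether the group exchanged was cyclic, aromatic or carried a hydroxy. A further exchange at that position is therefore expected to leave this assay within the scatter of compound 1, with no direction favoured. Compound 4 is estimated at 4800 nM, with a range of 1600 nM to 14000 nM, which corresponds to an expected step of no change at the digits printed from compound 1 to compound 4 (within the scatter).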

Compound 4, inhibition constant: 1500 nM
Estimate against measurement, compound 4: 3.2-fold (0.51 log units) above, outside the stated range (below it).
By their numbers in this assay, from the lowest: compound 4; then compounds 2, 1 and 3 (each within the scatter of the next).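

In this assay, the saturated chain carbon bound to a carbonyl carbon now proves able to move the number: (2,4-dichlorophenyl)sulfanyl in place of (cyclohexylamino)methyl gives a 3.2-fold lower number from compound 1 to compound 4 (0.51 log units; beyond the scatter), in place of 4-hydroxyphenoxy gives a 3.1-fold lower number from compound 2 to compound 4 (0.49 log units; beyond the scatter), and in place of cyclohexylmethyl gives a 3.8-fold lower number from compound 3 to compound 4 (0.58 log units; beyond the scatter). All three steps are modest but beyond the scatter, so compound 4 stands alone as the strongest of the four, and an aromatic ring on this chain is not enough by itself, since compound 2 also carries one and remains within the scatter of compound 1 and compound 3. No available evidence accounts for this shift.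

The sulfur and the two chlorines enter together in compound 4, so the compounds shown do not separate their contributions to the step. On these data alone, how a phenylsulfanyl group without chlorine, or a 2,4-dichlorophenoxy group, would read in this assay remains open, and either would help to divide the step between those parts.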